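Amide nitrogen substituent series: cyclobutyl, 1-phenylethyl, methyl

A few compounds are considered here, and "the series" means these few. Any claim that something is new, unique, unknown or untested is made for them only; others in the source may bear on it.

Measured so far:
compound 1 `O=C(/C=C/c1ccc(NC(=O)Nc2ccc(Cl)c(C(F)(F)F)c2)cc1)NC1CCC1` — 4530 nM
compound 2 `CC(NC(=O)/C=C/c1ccc(NC(=O)Nc2ccc(Cl)c(C(F)(F)F)c2)cc1)c1ccccc1` — 3130 nM

In a functional assay on MX1 cells (Homo sapiens) for inhibition, read by MTT assay, with a stated time of 120 h (a higher number here means a weaker inhibitor, a lower number a stronger inhibitor), compound 2 gives the lowest of the two numbers measured, but the step of a 1.4-fold lower number from compound 1 to compound 2 (0.16 log units; within the scatter) is within the scatter, so no order between compound 1 and compound 2 can be claimed. Compound 3 `CNC(=O)/C=C/c1ccc(NC(=O)Nc2ccc(Cl)c(C(F)(F)F)c2)cc1` carries methyl in place of 1-phenylethyl on an amide-type nitrogen. Among the compounds with values here, only one step bears on this position, and it was within the scatter, so no direction is established; the remaining cyclobutyl-to-methyl shrink is unexplored. Compound 3 is expected to stay near compound 2, the estimated step of a 1.6-fold higher number from compound 2 to compound 3 (0.20 log units; within the scatter), giving 5000 nM with a range of 2000 nM to 15000 nM.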

Compound 3, half-maximal inhibitory concentration: 13800 nM
Beside the measured number, compound 3's estimate is 2.8-fold (0.44 log units) below it, and the stated range covers the measured number.
By their numbers in this assay, from the lowest: compounds 2 and 1 (each within the scatter of the next); then compound 3.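

Methyl on the amide-type nitrogen reads weaker in this assay than either 1-phenylethyl or cyclobutyl, with a 4.4-fold higher number from compound 2 to compound 3 (0.64 log units; beyond the scatter) and a 3.0-fold higher number from compound 1 to compound 3 (0.48 log units; beyond the scatter) as modest steps beyond the scatter. This position therefore responds to its substituent, which the first pair could not show, although 1-phenylethyl and cyclobutyl remain within the scatter of each other and give no graded order. No available evidence explains this difference.

Open, as far as these compounds go, is whether a longer chain such as n-butyl, or a benzyl group, would stay with compound 1 and compound 2 or fall nearer compound 3.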